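From Propyl to Phenyl on the Aromatic Nitrogen

A few compounds are considered here, and "the series" means these few. Any claim that something is new, unique, unknown or untested is made for them only; others in the source may bear on it.

Of the compounds shown here, two have been tested so far in a toxicity assay on THP-1 cells (Homo sapiens) for inhibition; on this read-out higher numbers stand for lower toxicity in this test and lower numbers for higher toxicity in this test: compound 1 `COc1ccc(-c2cnc(NC(=O)c3ccc(F)cc3)n2Cc2ccccc2)cc1` and compound 2 `CCCn1c(-c2ccc(OC)cc2)cnc1NC(=O)c1ccc(F)cc1`. Compound 1 gives > 100000 nM, which is a limit of the assay and not a number. Compound 2 gives > 100000 nM, which is also a limit. Compound 2 thus stands at the limit of > 100000 nM in this assay, at which 2 of the 2 values shown sit.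

The next compound, compound 3 `COc1ccc(-c2cnc(NC(=O)c3ccc(F)cc3)n2-c2ccccc2)cc1`, has phenyl in place of propyl on an aromatic nitrogen. Going by the values given here, the only measured step that bears on this change is a step that the two limits leave unreadable from compound 1 to compound 2, which alters the group on that same nitrogen. Its size cannot be read, so it gives no measure for the new step. With both values at the limit, no step beyond the scatter is expected in this assay. The expected change is a number no higher from compound 2 to compound 3 (the limit leaves the size open). Compound 3 is estimated at 100000 nM, with an expected range of 40000 nM to 250000 nM.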

Compound 3, half-maximal cytotoxic concentration: 8800 nM
Compound 3: the middle estimate sits 11-fold (1.06 log units) above what was measured, and the stated range ends above it.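

In this assay, the group on the aromatic nitrogen proves able to change the read-out: phenyl in place of propyl gives an at least 11-fold lower number from compound 2 to compound 3 (1.05 log units; beyond the scatter), and phenyl in place of benzyl gives an at least 11-fold lower number from compound 1 to compound 3 (1.05 log units; beyond the scatter). Benzyl also carries a six-membered aromatic ring of carbon only, so among these compounds, such a ring alone does not go with the lower number; only phenyl, with no saturated chain carbon before the ring, does. Compound 1 and compound 2 both remain at a limit of the assay, so the step between them cannot be read: the limit of > 100000 nM in this assay, at which 2 of the 3 values shown sit.

The compounds shown leave open whether cyclohexyl or a pyridyl ring on this nitrogen would also give a lower number. They also leave open whether a fluorine or a methyl group on the entering phenyl would move the value of compound 3.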